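The source may hold more compounds than are shown below. What is called first, only, known or untested is meant among the compounds shown, and "the series" means these compounds.

Measured in a functional assay on MDA-MB-231 cells (Homo sapiens) for inhibition, read by sulforhodamine B assay, tested at 10 uM; a lower number here means less inhibition, a higher number more inhibition at the concentration tested (going by the name of the read-out):

compound 1 `Cc1ccc(C(=O)N2N=C(c3ccc(N4CCN(C)CC4)cc3)CC2c2ccc(N(C)C)cc2)cc1` gives -0.7%
compound 2 `CN1CCN(c2ccc(C3=NN(C(=O)c4ccc(F)cc4)C(c4ccc(N(C)C)cc4)C3)cc2)CC1` gives 3.5%
compound 3 `Cc1ccc(S(=O)(=O)N2N=C(c3ccc(-n4cncn4)cc3)CC2c2ccc(N(C)C)cc2)cc1` gives 20.7%

Compound 1 and compound 2 share one core. Compound 2 carries fluoro in place of methyl on an aromatic carbon, and this change gives a number 4.2 percentage points higher from compound 1 to compound 2 (within the scatter). Compound 3 rests on another core; the difference between the two cores is not broken down here. Compound 3 stands highest of the three numbers, with compound 2 nearest and below it beyond the scatter, and compound 1 furthest and also beyond the scatter.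

Compound 4 `CN(C)c1ccc(C2CC(c3ccc(-n4cncn4)cc3)=NN2S(=O)(=O)c2ccc(F)cc2)cc1` has not been measured. It differs from compound 3 by fluoro in place of methyl on an aromatic carbon, the same change as from compound 1 to compound 2. Cut one bond further out, it reads (4-methylphenyl)sulfonyl to (4-fluorophenyl)sulfonyl in the new pair, against (4-methylphenyl)carbonyl to (4-fluorophenyl)carbonyl in the measured pair. Among the measured compounds shown here, only this one measured instance of the change exists, so any expectation rests on it alone.

In this assay the step expected from compound 3 to compound 4 is a number 4.3 percentage points higher from compound 3 to compound 4 (within the scatter), a small shift within the scatter, because the earlier instance gave a number 4.2 percentage points higher from compound 1 to compound 2 (within the scatter). Compound 4 is accordingly estimated at 25%, with an expected range from 10% to 40%.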

Compound 4, a percentage reported as inhibition, at one concentration (the size of the read-out at that concentration, not a potency): 12.1%
For compound 4 the middle estimate is 12.9 percentage points above the measured one, within the range that was stated.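

In this assay the change from (4-methylphenyl)sulfonyl to (4-fluorophenyl)sulfonyl gives a number 8.6 percentage points lower from compound 3 to compound 4 (within the scatter) and so, like the earlier change on the carbonyl side, does not stand out from repeat measurement. The two instances of fluoro in place of methyl point in opposite directions on paper, but they cannot be told apart: the same change on two cores in this assay, a number 4.2 percentage points higher (within the scatter) from compound 1 to compound 2 and a number 8.6 percentage points lower (within the scatter) from compound 3 to compound 4, 12.8 percentage points apart, within the scatter of two such steps. This fits a change that makes no readable difference on either core, yet two small steps do not fix its size or its sign, and a modest real difference between the two cores cannot be ruled out.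

On these data alone, all four compounds carry only methyl or fluoro at this place, para to a large group, so it remains open whether a larger or differently built substituent there, such as a methoxy, a nitrile or a carboxylic acid, would give a step beyond the scatter on either core. All the values are also sizes of the read-out at a single concentration, which leaves open how these compounds would rank by potency.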